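A Second Fluorine on the Benzyl Group

A few compounds are considered here, and "the series" means these few. Any claim that something is new, unique, unknown or untested is made for them only; others in the source may bear on it.

Compound 1 `Cc1cc(Nc2nc(NCc3ccc(Cl)cc3)nc3ccccc23)n[nH]1`: 380 nM
Compound 2 `Cc1ccc(CNc2nc(Nc3cc(C)[nH]n3)c3ccccc3n2)cc1`: 110 nM
Compound 3 `Cc1cc(Nc2nc(NCc3ccccc3F)nc3ccccc23)n[nH]1`: 110 nM

In an assay for inhibition of high affinity nerve growth factor receptor (Homo sapiens), read by HTRF, with a stated time of 30 min, in the presence of a further agent that is not named here (on this read-out higher numbers stand for weaker inhibition and lower numbers for stronger inhibition), compound 3 gives 110 nM, level with compound 2 at the digits shown and together with it the lowest of the three numbers; the change a 3.5-fold lower number from compound 1 to compound 3 (0.54 log units; beyond the scatter) separates it from compound 1. Compound 4 `Cc1cc(Nc2nc(NCc3cc(F)ccc3F)nc3ccccc23)n[nH]1` differs from compound 3 by fluoro in place of hydrogen on an aromatic carbon. The measured steps on the same benzyl group are a 3.5-fold lower number from compound 1 to compound 3 (0.54 log units; beyond the scatter) and no change at the digits printed from compound 2 to compound 3 (within the scatter); each swaps one substituted phenyl for another, and none adds a fluoro to a ring that already carries one, so they bear only loosely on this change. The expected step is a 1.1-fold lower number from compound 3 to compound 4 (0.04 log units; within the scatter), within the scatter. Compound 4 is expected to give 100 nM, ranging from 45 nM to 250 nM.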

Compound 4, half-maximal inhibitory concentration: 7.5 nM
Beside the measured number, compound 4's estimate is 13-fold (1.12 log units) above it; the whole stated range lies above it.
By their numbers in this assay, from the lowest: compound 4; then compounds 2 and 3 (each within the scatter of the next); then compound 1.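

In this assay, a fluoro para to the fluoro group already on the ring gives a 15-fold lower number from compound 3 to compound 4 (1.17 log units; beyond the scatter) and so moves the number far more than the earlier swaps of one substituted phenyl for another did. The 2,5-difluorophenyl group also stands clear of the other two benzyl substituents, with a 15-fold lower number from compound 2 to compound 4 (1.17 log units; beyond the scatter) and with a 51-fold lower number from compound 1 to compound 4 (1.70 log units; beyond the scatter) on the same read-out. Nothing available here accounts for the size of this step.

Going by these compounds, it remains open whether the second fluoro would have this effect on a ring without the first. On these data alone, it is also open whether a chloro, a methoxy or a nitrile at this place would match it.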